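The source may report more compounds than this note shows. Statements on the series, on what has been measured and on what is new or still open speak of the compounds shown alone.

Measured so far: compound 1 `c1ccc(-c2cn3cc(-c4ccco4)ccc3n2)cc1`, compound 2 `c1coc(-c2ccc3nc(-c4ccco4)cn3c2)c1`, compound 3 `Nc1cc(-c2ccco2)cn2cc(-c3ccco3)nc12`.

In an ADME assay on SH-SY5Y cells (Homo sapiens) for cytotoxicity, read by MTT assay, with a stated time of 72 h (a higher number here means that more compound is tolerated, a lower number that less compound is tolerated), compound 1 gives > 100000 nM, which is a limit of the assay and not a number. In this assay compound 2 gives 3000 nM. In this assay compound 3 gives 2270 nM. Compound 2 and compound 1 differ by phenyl in place of furan-2-yl on an aromatic carbon, and that change gave an at least 33-fold higher number from compound 2 to compound 1 (1.52 log units; beyond the scatter), a step that runs up to the limit of > 100000 nM in this assay, at which 1 of the 3 values shown sits. Compound 2 and compound 3 differ by amino in place of hydrogen on an aromatic carbon, which gave a 1.3-fold lower number from compound 2 to compound 3 (0.12 log units; within the scatter).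

Compound 4 `Nc1cc(-c2ccccc2)cn2cc(-c3ccco3)nc12` is not yet measured. It differs from compound 3 by phenyl in place of furan-2-yl on an aromatic carbon; this is the same kind of change as that from compound 2 to compound 1, but the place is not the same: there it sat on a five-membered aromatic ring with two nitrogens, next to the ring nitrogen, here on a six-membered aromatic ring with one nitrogen, meta to an amino group. Resting on an at least 33-fold higher number from compound 2 to compound 1 (1.52 log units; beyond the scatter), the step from compound 3 to compound 4 is expected to be an 18-fold higher number from compound 3 to compound 4 (1.25 log units; beyond the scatter), though the other place makes it less certain. Compound 4 is therefore estimated at 40000 nM, between 8000 nM and 150000 nM.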

Compound 4, half-maximal cytotoxic concentration: 500 nM
Compound 4: middle estimate off by 80-fold (1.90 log units), on the high side, outside the stated range (below it).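

In this assay, phenyl in place of furan-2-yl on the core that carries the amino group gave a 4.5-fold lower number from compound 3 to compound 4 (0.66 log units; beyond the scatter), so the earlier result did not carry over to this core, and the two steps run in opposite directions: the same change on two cores in this assay, an at least 33-fold higher number (1.52 log units; beyond the scatter) from compound 2 to compound 1 and a 4.5-fold lower number (0.66 log units; beyond the scatter) from compound 3 to compound 4, at least 150-fold (2.17 log units) apart, beyond the scatter of two such steps Compound 1 gives > 100000 nM, which is a limit of the assay and not a number: the limit of > 100000 nM in this assay, at which 1 of the 4 values shown sits. The two pairs differ both in the amino group and in the place of the change, so they do not show which of these separates the results, or why.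

The compounds shown leave open whether a carboxylic acid or a longer alkyl chain at this place would follow compound 4. They also leave open how an acylated amine in place of the amino group would behave.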